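From Chloro to Trifluoromethyl in Compound 3

The source may report more compounds than this note shows. Statements on the series, on what has been measured and on what is new or still open speak of the compounds shown alone.

In an ADME assay on HepG2 2.2.15 cells (Homo sapiens) for cytotoxicity, read by CCK-8 assay, with a stated time of 8 days (on this read-out higher numbers stand for lower toxicity in this test and lower numbers for higher toxicity in this test), compound 2 (`CCOc1ccc(-c2cc(NC(=O)c3ccc(Cl)cc3O)c[nH]c2=O)cc1`) gives 28600 nM and compound 1 (`Cc1cccc(-c2cc(NC(=O)c3ccc(C(F)(F)F)cc3O)c[nH]c2=O)c1`) gives 24200 nM so the two stand within the scatter of each other. Compound 3 (`CCOc1ccc(-c2cc(NC(=O)c3ccc(C(F)(F)F)cc3O)c[nH]c2=O)cc1`) has trifluoromethyl in place of chloro on an aromatic carbon, meta to a hydroxy group and para to a large group (trifluoromethyl in place of chloro on an aromatic carbon). For the measured compounds named here, no measured pair isolates this change. Compound 1 also bears trifluoromethyl, and no step beyond the scatter is expected in this assay in either direction. The expected change is a 1.1-fold lower number from compound 2 to compound 3 (0.04 log units; within the scatter) and stays inside the scatter. Compound 3 is estimated at 26000 nM (range 13000 nM to 52000 nM).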

Compound 3, half-maximal cytotoxic concentration: 22200 nM
The estimate for compound 3 lay 1.2-fold (0.07 log units) above the measured number; the range from low to high includes it.
By their numbers in this assay, from the lowest: compounds 3, 1 and 2 (each within the scatter of the next).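

In this assay the swap of chloro for trifluoromethyl on an aromatic carbon, meta to a hydroxy group and para to a large group, now has its own measured pair, which shows a 1.3-fold lower number from compound 2 to compound 3 (0.11 log units; within the scatter) and so no step beyond the scatter at this position. With trifluoromethyl held in place, 4-ethoxyphenyl in place of 3-methylphenyl gives a 1.1-fold lower number from compound 1 to compound 3 (0.04 log units; within the scatter) and likewise stays inside the scatter. No measurement shown offers an explanation for either step. The compounds shown leave open whether an amine or a carboxylic acid at this position would give a step beyond the scatter in this assay as well.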